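A few compounds are considered here, and "the series" means these few. Any claim that something is new, unique, unknown or untested is made for them only; others in the source may bear on it.

The compounds measured in this series are:

Compound 1, `COc1cc(NC(C)CCCNC(=O)NNC(=O)Nc2cc(C(F)(F)F)cc(C(F)(F)F)c2)c2ncccc2c1`, giving 13000 nM
Compound 2, `COc1cc(NC(C)CCCNC(=O)Nc2ccc(O)cc2)c2ncccc2c1`, giving 23000 nM
Compound 3, `COc1cc(NC(C)CCCNC(=O)NNC(=O)Nc2cccc(Cl)c2)c2ncccc2c1`, giving 81000 nM

In a functional assay on CCRF-CEM cells (Homo sapiens) for inhibition, read by MTT assay, with a stated time of 72 h (a lower number here means a stronger inhibitor, a higher number a weaker inhibitor), compound 2 stands second highest of the three numbers. Compound 1 lies within the usual scatter of compound 2, so the two cannot be told apart on these data. Among the measured compounds shown here, compound 3 is the farthest from it: the step of a 3.5-fold higher number from compound 2 to compound 3 (0.55 log units; beyond the scatter) is the only change beyond the scatter in the set, and it exchanges the whole 4-hydroxyphenyl group for a ((3-chlorophenyl)carbamoyl)amino group on the amide-type nitrogen.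

Compound 4, `COc1cc(NC(C)CCCNC(=O)Nc2ccc(Br)cc2)c2ncccc2c1`, has not yet been measured in this assay. It differs from compound 2 in one place:

bromo in place of hydroxy on an aromatic carbon

For the measured compounds named here, no measured step in this set changes only a single substituent on the aromatic ring, so the closest guide is the larger step from compound 2 to compound 3, which replaced the hydroxy-bearing ring entirely. The change to compound 4 is far smaller than that one, so a step of the size a 1.2-fold lower number from compound 2 to compound 4 (0.06 log units; within the scatter) is expected, with no clear direction beyond the scatter. Compound 4 is therefore estimated at 20000 nM, with a range from 7000 nM to 60000 nM.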

Compound 4, half-maximal inhibitory concentration: 23000 nM
Compound 4: middle estimate off by 1.2-fold (0.06 log units), on the low side, and the stated range covers the measured number.
By their numbers in this assay, from the lowest: compounds 1, 2 and 4 (each within the scatter of the next); then compound 3.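

In this assay, among the compounds shown here, the hydroxy on an aromatic carbon para to a large group gives way to bromo with no change at the digits printed from compound 2 to compound 4 (within the scatter) and nothing beyond the scatter, the first reading of a single-substituent change on this ring, even though hydroxy carries a hydrogen-bond donor and acceptor and bromo carries neither. The second new step, a 3.5-fold lower number from compound 3 to compound 4 (0.55 log units; beyond the scatter), matches in size the earlier 3.5-fold higher number from compound 2 to compound 3 (0.55 log units; beyond the scatter) and thus shows that compound 3 stands apart from the 4-bromophenyl compound as it does from the 4-hydroxyphenyl compound, so the gap between these compounds does not depend on which of the two substituents the phenyl ring carries. No measurement at hand explains why hydroxy and bromo read alike here.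

From the compounds shown here alone, whether an amine, a carboxylic acid or a methoxy group on this same aromatic carbon would also read like hydroxy and bromo remains open, as does the effect of moving bromo to another carbon of the ring. For the compounds shown here, also open is whether a longer chain in place of the one carrying the phenyl group would shift the number in either direction.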